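Trimming a methoxy from a trimethoxyphenyl pyrazoline

The source may hold more compounds than are shown below. What is called first, only, known or untested is meant among the compounds shown, and "the series" means these compounds.

Two compounds in this series carry the same core and differ only in how many methoxy groups sit on the phenyl ring. Compound 1 `COc1ccc(C2CC(c3ccco3)=NN2C(C)=O)cc1` carries one methoxy; in a functional assay on PC-3 cells (Homo sapiens) for cytotoxicity, read by sulforhodamine B assay, with a stated time of 48 h (on this read-out lower numbers stand for stronger inhibition and higher numbers for weaker inhibition), compound 1 gives 15500 nM. Compound 2 `COc1cc(C2CC(c3ccco3)=NN2C(C)=O)cc(OC)c1OC` carries three; in this assay compound 2 gives 9650 nM. Of the two numbers recorded, that of compound 2 is the lower one, yet the two values lie within the scatter of each other, so no difference in cytotoxicity between compound 1 and compound 2 can be claimed.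

Compound 3 `COc1ccc(C2CC(c3ccco3)=NN2C(C)=O)cc1OC` has not yet been measured. It is reached from compound 2 by hydrogen in place of methoxy on an aromatic carbon, leaving two methoxy groups on the ring. Going by the values given here, with no step between measured compounds available, the account rests on the two values alone: they show that going from one to three methoxy groups barely moved the number, so compound 3, sitting between them in substitution, is expected to fall close to both, and the step of a 1.2-fold higher number from compound 2 to compound 3 (0.08 log units; within the scatter) is estimated to stay within the scatter. Compound 3 is expected to give about 11500 nM, with a range from 5000 nM to 26000 nM.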

Compound 3, half-maximal inhibitory concentration: 12300 nM
Beside the measured number, compound 3's estimate is 1.1-fold (0.03 log units) below it; measured number inside the range.
By their numbers in this assay, from the lowest: compounds 2, 3 and 1 (each within the scatter of the next).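

Replacing this methoxy, ortho to a methoxy group and meta to a large group, with hydrogen in this assay gives a 1.3-fold higher number from compound 2 to compound 3 (0.11 log units; within the scatter) and, unlike the earlier comparison of compound 1 with compound 2, which spans two methoxy groups at once, isolates a single ring position. The other single-group step, methoxy in place of hydrogen on an aromatic carbon, gives a 1.3-fold lower number from compound 1 to compound 3 (0.10 log units; within the scatter) and also stays within the scatter, so neither one-group change produces a difference that can be claimed, and the ring tolerates one, two or three methoxy groups alike in this assay. No available evidence bears on the reason for this flat response.

As far as these compounds go, these three compounds test only methoxy and hydrogen on the phenyl ring, so it remains open whether a hydroxyl, an amine, a carboxylic acid or a longer alkoxy chain at this position would move the number beyond the scatter. From the compounds shown here alone, it also remains open whether changes elsewhere on the shared core would have a larger effect than these methoxy changes.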